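A few compounds are considered here, and "the series" means these few. Any claim that something is new, unique, unknown or untested is made for them only; others in the source may bear on it.

Working notes on the series. Compound 1 `O=C1CC(c2nc(-c3cccc(Cl)c3)no2)CN1c1ccc(Cl)c(Cl)c1` in an in vitro functional assay on HEK293-A cells for negative allosteric modulation of metabotropic glutamate receptor 5 (Homo sapiens), read by FLIPR and calcium flux (on this read-out higher numbers stand for weaker inhibition and lower numbers for stronger inhibition), gives > 10000 nM, a limit of the assay rather than a number. Compound 2 `Cc1ccc(N2CC(c3nc(-c4cccc(Cl)c4)no3)CC2=O)cc1C` in this assay gives > 10000 nM, again only a limit. Among the measured compounds shown here, compound 3 `Cc1ccccc1N1CC(c2nc(-c3cccc(Cl)c3)no2)CC1=O` in this assay gives 370 nM, the only number among the three. The two other values sit at the limit of > 10000 nM in this assay, at which 2 of the 3 values shown sit. The change of the aryl group on the ring nitrogen is read as an at least 27-fold lower number from compound 1 to compound 3 (1.43 log units; beyond the scatter) and as an at least 27-fold lower number from compound 2 to compound 3 (1.43 log units; beyond the scatter), while the step that the two limits leave unreadable from compound 1 to compound 2.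

Compound 4 `COc1cccc(N2CC(c3nc(-c4cccc(Cl)c4)no3)CC2=O)c1` is the next member, not yet measured, and differs from compound 3 by 3-methoxyphenyl in place of 2-methylphenyl on an amide-type nitrogen in a ring. For the measured compounds named here, no measured step exchanges one phenyl carrying a single group for another; the two readable steps show only that 2-methylphenyl gave a large gain over 3,4-dichlorophenyl and over 3,4-dimethylphenyl, so the methoxy variant has no direct precedent here. The expectation for compound 4 in this assay is a moderate step of a 5.4-fold higher number from compound 3 to compound 4 (0.73 log units; beyond the scatter), toward a higher number, with a fair chance of a limit. The estimated value for compound 4 is 2000 nM, within 500 nM to 8000 nM.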

Compound 4, half-maximal inhibitory concentration: 690 nM
Estimate against measurement, compound 4: 2.9-fold (0.46 log units) above; the measured number falls inside the stated range.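

In this assay a second phenyl carrying a single group now stands on the amide-type nitrogen, and the exchange of 2-methylphenyl for 3-methoxyphenyl stays within the scatter: a 1.9-fold higher number from compound 3 to compound 4 (0.27 log units; within the scatter). The large gain is therefore not confined to 2-methylphenyl, as the comparisons with the two disubstituted phenyls show: an at least 14-fold lower number from compound 2 to compound 4 (1.16 log units; beyond the scatter), and an at least 14-fold lower number from compound 1 to compound 4 (1.16 log units; beyond the scatter). Compound 1 and compound 2 each give a limit and not a number, so both of these steps are bounds only: the limit of > 10000 nM in this assay, at which 2 of the 4 values shown sit.

The compounds shown leave open how far the reading depends on where the single group sits, since neither methyl nor methoxy appears at a second place on the phenyl. Also open, as far as these compounds go, is how this position responds to an unsubstituted phenyl, or to a phenyl bearing an amine or a carboxylic acid.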